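The compounds below may be only part of what the source reports. "The series", "measured", "known", "first", "only" and "open" are said of these compounds alone.

Measured so far in a functional assay on B16-F10 cells (Mus musculus) for cytotoxicity, read by MTT assay, with a stated time of 48 h; a lower number here means a stronger inhibitor, a higher number a weaker inhibitor:
Compound 1 `COc1ccc(-c2nc(C(=O)/C=C\Nc3ccc4[nH]ccc4c3)c3ccccn23)cc1` gives 5120 nM
Compound 2 `O=C(/C=C\Nc1ccc2cc[nH]c2c1)c1nc(-c2ccc(C(F)(F)F)cc2)n2ccccc12` gives > 30000 nM
Compound 3 `O=C(/C=C\Nc1cnc2ccccc2c1)c1nc(-c2ccccc2)n2ccccc12` gives 3780 nM

Of the two compounds with a plain number, compound 1 has the higher one, but its gap to compound 3 lies within the scatter of repeated measurements, so the two cannot be ranked. For compound 2 the result is the limit of > 30000 nM in this assay, at which 1 of the 3 values shown sits, a limit rather than a measured number.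

Compound 4 `COc1ccc(N/C=C\C(=O)c2nc(-c3ccc(OC)cc3)n3ccccc23)cc1` has not yet been measured. It differs from compound 1 in one place: 4-methoxyphenyl in place of 1H-indol-5-yl on an amine nitrogen. Among the compounds with values here, no measured pair shows this change, so its effect is uncertain; a modest weakening is expected, with the step of a 1.8-fold higher number from compound 1 to compound 4 (0.24 log units; within the scatter) estimated to fall a little beyond the scatter. Compound 4 is therefore expected at about 9000 nM, within a range of 3000 nM to 27000 nM.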

Compound 4, half-maximal inhibitory concentration: 2120 nM
Compound 4: the middle estimate sits 4.2-fold (0.63 log units) above what was measured, outside the stated range (below it).
By their numbers in this assay, from the lowest: compounds 4, 3 and 1 (each within the scatter of the next, the first and the last beyond it). At a limit, above all of these: compound 2.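

In this assay, the amine nitrogen does not need 1H-indol-5-yl: 4-methoxyphenyl in its place gives a 2.4-fold lower number from compound 1 to compound 4 (0.38 log units; beyond the scatter), a modest step but one beyond the scatter. A single six-membered ring therefore serves here, without the five-membered ring or its hydrogen-bond donor. Nothing measured here accounts for the change.

As far as these compounds go, whether the methoxy group matters, or only the loss of the five-membered ring, remains open. A plain phenyl or a 4-carboxyphenyl group on the same nitrogen would separate these two readings.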